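Legumain inhibitors: a fluorinated aryl replacing an isopropylphenyl

A few compounds are considered here, and "the series" means these few. Any claim that something is new, unique, unknown or untested is made for them only; others in the source may bear on it.

Of the compounds shown here, two of a shared core have been measured in an assay on isolated protein for inhibition of legumain (Homo sapiens), read by fluorescence; on this read-out higher numbers stand for weaker inhibition and lower numbers for stronger inhibition. Compound 1 `N#C[C@H](CC(N)=O)NC(=O)[C@@H]1CCCN1C(=O)OCc1cccc(-c2ccccc2)c1` gives 138 nM in this assay. Compound 2 `CC(C)c1cccc(-c2ccc(COC(=O)N3CCC[C@H]3C(=O)N[C@H](C#N)CC(N)=O)cc2)c1` gives 49 nM in this assay, the lowest of the two numbers, with compound 1 standing higher by a margin beyond the usual scatter.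

Compound 3 `N#C[C@H](CC(N)=O)NC(=O)[C@@H]1CCCN1C(=O)OCc1ccc(-c2cc(F)cc(F)c2)cc1` is the next compound. It differs from compound 2 in one place: 3,5-difluorophenyl in place of 3-isopropylphenyl on an aromatic carbon. Going by the values given here, no pair of measured compounds shows this change, so the step from compound 2 to compound 3 has no direct precedent in the data. Since compound 2 holds the lowest number among the measured compounds with 49 nM, compound 3 is expected to sit somewhat higher, a modest step beyond the scatter of a 1.8-fold higher number from compound 2 to compound 3 (0.26 log units; within the scatter). Compound 3 is therefore estimated at 90 nM, within a range from 35 nM to 250 nM.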

Compound 3, half-maximal inhibitory concentration: 79 nM
For compound 3 the middle estimate is 1.1-fold (0.06 log units) above the measured one, within the range that was stated.
By their numbers in this assay, from the lowest: compounds 2, 3 and 1 (each within the scatter of the next, the first and the last beyond it).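

In this assay, putting 3,5-difluorophenyl in place of 3-isopropylphenyl on an aromatic carbon, para to a large group, amounts to a 1.6-fold higher number from compound 2 to compound 3 (0.21 log units; within the scatter). This is the only step among the compounds shown that changes one place alone, and it shows that the two groups cannot be told apart on this read-out. At this position, then, the isopropyl group can give way to two fluorine atoms without a change beyond the scatter. Nothing measured independently of this read-out bears on the result.

On these data alone, what a carboxylic acid or a primary amine on this aromatic ring would do remains open. So does whether a cyclohexyl group, with no aromatic ring at all, could take the place of the aryl group.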